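The compounds below may be only part of what the source reports. "The series", "measured", "known", "first", "only" and "open" are said of these compounds alone.

Of the compounds shown here, three with a shared aryl sulfonamide arm have been measured in an ADME assay for inhibition of prostaglandin G/H synthase 1 (Rattus norvegicus), with a stated time of 30 min; a higher number here means a weaker inhibitor, a lower number a stronger inhibitor. Compound 1 `CN1C=CN(C2SC(C(Cl)(Cl)Cl)=CN2c2ccc(S(N)(=O)=O)cc2)C=C1` gives 88600 nM. Compound 2 `CN1C=CC(C2SC(C(F)(F)F)=CN2c2ccc(S(N)(=O)=O)cc2)C=C1` gives 80500 nM. Compound 3 `CC1=CN(c2ccc(S(N)(=O)=O)cc2)C(N2C=CN(C)C=C2)N1` gives 90700 nM. The number for compound 2 is the lowest of the three, but its gaps to compound 1 and to compound 3 both fall inside the usual scatter of this assay, so the three compounds cannot be told apart on these data; all three are weak inhibitors.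

Compound 4 `CN1C=CN(C2SC(C(F)(F)F)=CN2c2ccc(S(N)(=O)=O)cc2)C=C1` has not yet been measured. It differs from compound 2 by a group of 7 heavy atoms (5 carbon, 2 nitrogen; one six-membered non-aromatic ring with 2 hetero atoms) in place of a group of 7 heavy atoms (6 carbon, 1 nitrogen; one six-membered non-aromatic ring with 1 hetero atom), on a saturated ring carbon. Among the compounds with values here, no pair of measured compounds shows this change on its own, so its effect in this assay is not known from the data. Since compounds 1, 2 and 3, with varied cores and side groups, all sit at nearly the same weak level, no step beyond the scatter is expected here, and the change from compound 2 to compound 4 is estimated at a 1.0-fold higher number from compound 2 to compound 4 (0.01 log units; within the scatter). Compound 4 is therefore expected to give about 82000 nM in this assay, with a likely range from 40000 nM to 170000 nM.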

Compound 4, half-maximal inhibitory concentration in the prostaglandin G/H synthase 1 assay: 52400 nM
Compound 4: middle estimate off by 1.6-fold (0.19 log units), on the high side; the measured number falls inside the stated range.
By their numbers in the prostaglandin G/H synthase 1 assay, from the lowest: compounds 4, 2, 1 and 3 (each within the scatter of the next).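

In the prostaglandin G/H synthase 1 assay, the exchange of one six-membered ring group for the other on the saturated ring carbon gives a 1.5-fold lower number from compound 2 to compound 4 (0.19 log units; within the scatter), and trifluoromethyl in place of trichloromethyl on the double-bonded ring carbon gives a 1.7-fold lower number from compound 1 to compound 4 (0.23 log units; within the scatter). These two pairs each isolate a single change, and both steps lie within the scatter, so neither change can be said to alter inhibition on these data. In a physicochemical assay for lipophilicity (on this read-out lower numbers stand for lower lipophilicity and higher numbers for higher lipophilicity), compound 2 gives 2.77 and compound 4 gives 2.38. At the saturated ring carbon, the exchange thus cannot be resolved in the prostaglandin G/H synthase 1 assay, while it does separate the two compounds in the physicochemical assay, where compound 4 is the less lipophilic: the measured partition coefficient of compound 2, 2.77, and of compound 4, 2.38, a number 0.39 log units lower (beyond the scatter)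

The compounds shown do not tell whether an amine or a carboxylic acid on the saturated ring carbon, or a nitrile in place of trifluoromethyl on the double-bonded ring carbon, would produce a step beyond the scatter in the prostaglandin G/H synthase 1 assay. Also open, on these data alone, is whether a larger drop in the physicochemical assay than this one would be accompanied by a readable step in the prostaglandin G/H synthase 1 assay.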